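Swapping cyano for acetamido in a growth inhibition series

The compounds below may be only part of what the source reports. "The series", "measured", "known", "first", "only" and "open" are said of these compounds alone.

Measured so far in a functional assay on A549 cells (Homo sapiens) for inhibition, read by sulforhodamine B assay, with a stated time of 48 h, tested at 50 uM (a higher number here means more inhibition of growth at the concentration tested, a lower number less inhibition of growth), for each compound:
- compound 1 `COc1ccc([C@@H]2C/C(=N/OCc3cn(-c4ccc(C#N)cc4)nn3)c3cc(CC=C(C)C)c(OC)cc3O2)cc1` gives 42%
- compound 2 `COc1ccc([C@@H]2C/C(=N/O)c3cc(CC=C(C)C)c(OC)cc3O2)cc1` gives 66%
- compound 3 `COc1cc2c(cc1CC=C(C)C)C(=O)C[C@@H](c1ccc(Oc3cccc([N+](=O)[O-])c3)cc1)O2` gives 37%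

Compound 1 (42%) lies within the scatter of compound 3 (37%), while compound 2 (66%) stands higher, beyond the scatter. Going on to compound 4 `COc1ccc([C@@H]2C/C(=N/OCc3cn(-c4ccc(NC(C)=O)cc4)nn3)c3cc(CC=C(C)C)c(OC)cc3O2)cc1`, acetamido takes the place of cyano on an aromatic carbon, para to a large group (acetamido in place of cyano on an aromatic carbon), which reads as 4-cyanophenyl to 4-acetamidophenyl. Within the data shown here, no measured pair shows this change, so the step in this assay has no direct precedent, and none beyond the scatter is expected. Compound 1 at 42% serves as the closest measured guide, and it differs from compound 4 only in that group. The estimated step reads a number 1 percentage points lower from compound 1 to compound 4 (within the scatter) and stays within the scatter. For compound 4 the estimated value is 41%, with an expected range from 25% to 58% in this read-out.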

Compound 4, percent growth inhibition at one concentration: 19%
The estimate for compound 4 lay 22 percentage points above the measured number; measured number below the stated range.
By their numbers in this assay, from the lowest: compound 4; then compounds 3 and 1 (each within the scatter of the next); then compound 2.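

Among these compounds, the change from 4-cyanophenyl to 4-acetamidophenyl gives a number 23 percentage points lower from compound 1 to compound 4 (beyond the scatter) in this assay and provides the first comparison between compounds that differ in one place. With the rest of the structure unchanged, the group on this aromatic carbon, para to a large group, clearly matters to growth inhibition, and acetamido reads worse here than cyano. No supporting data bear on the reason for this step.

From the compounds shown here alone, it remains open whether an amine or a carboxylic acid on the same carbon would read nearer to compound 1 or to compound 4. The effect of the change also rests on this single pair, so whether it carries over to another pair with the same swap is unsettled.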